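The source may hold more compounds than are shown below. What is called first, only, known or untested is meant among the compounds shown, and "the series" means these compounds.

Measured so far:
- compound 1, `CCC(C)n1ncn(-c2ccc(N3CCN(c4ccc(OC[C@@H]5CO[C@@](Cn6cncn6)(c6ccc(Cl)cc6Cl)O5)cc4)CC3)nc2)c1=O`: 0.0539 ug/mL
- compound 2, `CCC(C)n1ncn(-c2ccc(N3CCN(c4ccc(OC[C@@H]5CO[C@@](Cn6cncn6)(c6ccc(Cl)cc6Cl)O5)cc4)CC3)cn2)c1=O`: 0.497 ug/mL
- compound 3, `CCC(C)n1ncn(-c2ccc(N3CCN(c4ccc(OC[C@@H]5CO[C@@](Cn6ccnc6)(c6ccc(Cl)cc6Cl)O5)cc4)CC3)nc2)c1=O`: 7.99 ug/mL

All values come from a physicochemical assay for solubility, read by HPLC, measured as thermodynamic solubility; a lower number here means a less soluble compound, a higher number a more soluble compound. Compound 1 and compound 2 share the same atoms joined differently; the difference between the two cores is not broken down here. Their values alone show compound 2 standing higher than compound 1, with a gap beyond the scatter.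

Among the measured compounds shown here, the one change that is tracked across the set is 1H-imidazol-1-yl in place of 1H-1,2,4-triazol-1-yl on a saturated chain carbon bound to a saturated ring carbon. It gives a 150-fold higher number from compound 1 to compound 3 (2.17 log units; beyond the scatter). The same change, at the same place word for word, leads from compound 2 to the not yet measured compound 4, `CCC(C)n1ncn(-c2ccc(N3CCN(c4ccc(OC[C@@H]5CO[C@@](Cn6ccnc6)(c6ccc(Cl)cc6Cl)O5)cc4)CC3)cn2)c1=O`: 1H-imidazol-1-yl in place of 1H-1,2,4-triazol-1-yl on a saturated chain carbon bound to a saturated ring carbon.

Compound 2 already sits higher than compound 1 in this assay, so the question is whether the step seen from compound 1 to compound 3 carries over onto the core of compound 2. For the measured compounds named here, with only one measured instance of the change, the expectation rests on that single step; it is taken as a guide, not a rule, and a somewhat smaller step is allowed for.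

The step from compound 2 to compound 4 in this assay is expected to be a 100-fold higher number from compound 2 to compound 4 (2.00 log units; beyond the scatter), resting on a 150-fold higher number from compound 1 to compound 3 (2.17 log units; beyond the scatter) applied to compound 2 at 0.497 ug/mL. Compound 4 is therefore estimated at 50 ug/mL, with a likely range from 12 ug/mL to 150 ug/mL.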

Compound 4, solubility: 41.3 ug/mL
Beside the measured number, compound 4's estimate is 1.2-fold (0.08 log units) above it, and the stated range covers the measured number.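

In this assay, 1H-imidazol-1-yl in place of 1H-1,2,4-triazol-1-yl on a saturated chain carbon bound to a saturated ring carbon gives an 83-fold higher number from compound 2 to compound 4 (1.92 log units; beyond the scatter) and so repeats, in direction and as a large step, a 150-fold higher number from compound 1 to compound 3 (2.17 log units; beyond the scatter) on the other core. The change has therefore carried over between the two cores shown, with both steps beyond the scatter, although these two cores share the same atoms and differ only in how those atoms are joined; two matched pairs set no rule for a core that differs more widely, and they do not show that the step would keep its size elsewhere. The data offer nothing that explains the step on either core.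

The compounds shown carry only 1H-1,2,4-triazol-1-yl and 1H-imidazol-1-yl at this place, so it remains open how a 1H-pyrazol-1-yl group or an open-chain amine there would stand in this assay. Also open is whether a step of this kind would appear on a core carrying a carboxylic acid or a longer chain, as the two pairs shown cannot speak to either.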